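Swapping Fluoro for Methoxy on Two Related Amide Cores

A few compounds are considered here, and "the series" means these few. Any claim that something is new, unique, unknown or untested is made for them only; others in the source may bear on it.

Measured so far:
Compound 1, `O=C(COc1c(-c2ccccc2)oc2ccccc2c1=O)Nc1ccc(F)cc1`: in a functional assay on MT2 cells (Homo sapiens) for antiproliferative activity, read by MTT assay, with a stated time of 72 h (on this read-out higher numbers stand for weaker inhibition of growth and lower numbers for stronger inhibition of growth), compound 1 gives > 10000 nM, which is a limit of the assay rather than a number.
Compound 2, `COc1ccc(NC(=O)COc2c(-c3ccccc3)oc3ccccc3c2=O)cc1`: compound 2 gives > 10000 nM, again a limit of the assay.
Compound 3, `O=C(COc1ccc2c(=O)cc(-c3ccccc3)oc2c1)Nc1ccc(F)cc1`: compound 3 gives 6410 nM.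

Compound 1 and compound 2 share one core and differ in a single place: methoxy in place of fluoro on an aromatic carbon. Both values sit at the limit, so the step that the two limits leave unreadable from compound 1 to compound 2 cannot be read from them. Compound 3 is built from the same atoms as compound 1 joined differently; the difference between the two cores is not broken down here.

Compound 4, `COc1ccc(NC(=O)COc2ccc3c(=O)cc(-c4ccccc4)oc3c2)cc1`, has not yet been measured. It differs from compound 3 by methoxy in place of fluoro on an aromatic carbon. The surroundings of the change are described in the same words for both pairs, so this is the same change made a second time, now on the core of compound 3.

The earlier pass gave no readable size. Among the three values, only compound 3 yields a number, and that number lies not far from the limit (the limit of > 10000 nM in this assay, at which 2 of the 3 values shown sit). The step expected for this change is therefore taken as small, a 1.2-fold higher number from compound 3 to compound 4 (0.10 log units; within the scatter), resting on compound 3 giving 6410 nM and on the unreadable first pass.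

Compound 4 is estimated at 8000 nM, with a likely range from 3000 nM to 20000 nM, and a real chance that only a limit is reported.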

Compound 4, concentration for 50% growth inhibition: 6700 nM
For compound 4 the middle estimate is 1.2-fold (0.08 log units) above the measured one; the range from low to high includes it.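

On the core of compound 3, putting methoxy in place of fluoro gives a 1.0-fold higher number from compound 3 to compound 4 (0.02 log units; within the scatter) in this assay, so on this core the two groups cannot be told apart by this read-out, and a 4-fluorophenyl and a 4-methoxyphenyl serve equally well here. This is a single readable case, and it does not show that the two groups can be exchanged freely on any core in this series, nor does it say why the values agree. The same change on the core of compound 1 cannot be read, so there is no second size to set beside the first and no way to tell whether the change carries over from one core to the other: the limit of > 10000 nM in this assay, at which 2 of the 4 values shown sit.

The compounds shown place only fluoro and methoxy on this aromatic carbon, so it remains open whether any group there can move the value beyond the usual scatter of the measurement. What an amine, a carboxylic acid or a longer chain such as butoxy would do at that place on the core of compound 3 is an open question.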